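From Nitro to Bromo on a Shared Core

The source may hold more compounds than are shown below. What is called first, only, known or untested is meant among the compounds shown, and "the series" means these compounds.

Of the compounds shown here, three have been measured in a functional assay on HCT-8 cells (Homo sapiens) for cytotoxicity, read by MTT assay, with a stated time of 48 h; on this read-out higher numbers stand for weaker inhibition and lower numbers for stronger inhibition. Compound 1 `CN1CCC(NC(=O)c2ccc(Nc3ncc([N+](=O)[O-])c(NC4CCCC4)n3)cc2)CC1` gives 15600 nM, the lowest of the three numbers. Compound 2 `CN1CCN(c2ccc(Nc3ncc(F)c(NC4CCCC4)n3)cc2)CC1` gives 29000 nM, a number within the scatter of compound 1. Among the compounds with values here, compound 3 `CCCNc1nc(Nc2ccc(N3CCN(C)CC3)cc2)ncc1F` gives 50000 nM, the only number whose gap to compound 1 goes beyond the scatter. Within the data shown here, the single step between compounds that differ in one place, a 1.7-fold higher number from compound 2 to compound 3 (0.24 log units; within the scatter), concerns the group on the ring nitrogen and not the position that matters here.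

Compound 4 `CN1CCC(NC(=O)c2ccc(Nc3ncc(Br)c(NC4CCCC4)n3)cc2)CC1` differs from compound 1 in one place: bromo in place of nitro on an aromatic carbon. Among the measured compounds shown here, no measured pair exchanges one group for another at this position; compounds 1 and 2 carry different groups there but also differ elsewhere, so their two values only show numbers within the scatter of each other. For the measured compounds named here, with no step bearing on this exchange, compound 4 is expected to stay close to compound 1, with the change a 1.0-fold lower number from compound 1 to compound 4 (0.02 log units; within the scatter) lying within the scatter. The estimate for compound 4 in this assay is therefore 15000 nM, ranging from 5000 nM to 50000 nM.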

Compound 4, half-maximal inhibitory concentration: 3600 nM
For compound 4 the middle estimate is 4.2-fold (0.62 log units) above the measured one; measured number outside the range, below it.
By their numbers in this assay, from the lowest: compound 4; then compounds 1, 2 and 3 (each within the scatter of the next, the first and the last beyond it).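

The aromatic carbon that carries nitro in compound 1 proves sensitive to the group placed on it: in this assay, bromo in place of nitro gives a 4.3-fold lower number from compound 1 to compound 4 (0.64 log units; beyond the scatter), the only step among these compounds that goes beyond the scatter. The exchange swaps nitro, with 3 heavy atoms and 2 hydrogen-bond acceptors, for bromo, with 1 heavy atom and 0 hydrogen-bond acceptors, but this single pair cannot show which of these differences counts. No measurement of any property of these compounds is available to account for the step.

Going by these compounds, whether a group such as chloro, a nitrile or an amine at this position would give a number like that of compound 4 remains open. On these data alone, compound 2 and compound 3 carry fluoro there but differ elsewhere, so how fluoro compares with bromo on the core of compound 1 also remains unknown.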